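From Bromo to Methoxy on a Shared Core

The source may report more compounds than this note shows. Statements on the series, on what has been measured and on what is new or still open speak of the compounds shown alone.

Compound 1 `Cc1ccc(S/C(=C/c2ccc(Br)cc2)C(=O)c2ccc(Cl)cc2)cc1` carries the highest number of the three measured compounds: in a functional assay on DU-145 cells (Homo sapiens) for inhibition, read by trypan blue exclusion, with a stated time of 96 h (a higher number here means a weaker inhibitor of growth, a lower number a stronger inhibitor of growth), compound 1 gives 25000 nM. Compound 2 `Cc1ccc(CS/C(=C/c2ccc(Br)cc2)C(=O)c2ccc(Cl)cc2)cc1` gives 10000 nM, a step of a 2.5-fold lower number from compound 1 to compound 2 (0.40 log units; beyond the scatter), and compound 3 `O=C(/C(=C\c1ccc(Br)cc1)SCc1ccc(F)cc1)c1ccc(Cl)cc1` gives 9000 nM, a step of a 2.8-fold lower number from compound 1 to compound 3 (0.44 log units; beyond the scatter). Compound 4 `COc1ccc(/C=C(/Sc2ccc(C)cc2)C(=O)c2ccc(Cl)cc2)cc1` differs from compound 1 in another place: methoxy in place of bromo on an aromatic carbon. Going by the values given here, both measured steps change only the group on the sulfur and leave the bromo untouched, so neither bears directly on this change; the data hold no example of swapping bromo for methoxy anywhere. With no guidance of that kind, the expected step of no change at the digits printed from compound 1 to compound 4 (within the scatter) is none beyond the scatter. Compound 4 is therefore estimated at 25000 nM, within a range from 8000 nM to 70000 nM.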

Compound 4, concentration for 50% growth inhibition: 1000 nM
For compound 4 the middle estimate is 25-fold (1.40 log units) above the measured one; measured number outside the range, below it.
By their numbers in this assay, from the lowest: compound 4; then compounds 3 and 2 (each within the scatter of the next); then compound 1.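

The earlier steps shown here changed only the group on the sulfur and moved the number modestly, whereas this change on the aromatic ring gives a 25-fold lower number from compound 1 to compound 4 (1.40 log units; beyond the scatter) in this assay. This makes the bromo position, on a ring carbon para to a large group, highly sensitive to what sits there. Nothing available explains why this swap has so large an effect.

The compounds shown leave open whether a hydroxyl, an ethoxy or an amine at this position would match methoxy. They also leave open whether methoxy would give a similar step on the benzyl compounds, compound 2 and compound 3.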